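Amide in place of alkylamine on a shared aminothiazole core

This account rests on a few compounds, and the source may have more. Where it says the series, first, only, none or still open, it means among the compounds named here.

Compound 1 `O=C(Nc1ncc(Cc2ccc(Br)cc2)s1)c1cccs1`: > 50000 nM
Compound 2 `CCCCC(CC)CNc1ncc(C(Oc2ccc3cc(Br)ccc3c2)c2ccc(Cl)cc2)s1`: "not toxic" (no number reported)

The study tests two compounds in an ADME assay on HepG2 2.2.15 cells (Homo sapiens) for cytotoxicity; a lower number here means that less compound is tolerated, a higher number that more compound is tolerated. Compound 1 reaches only the limit of the assay, with > 50000 nM, and no number. Compound 2 is reported in this assay simply as "not toxic" (no number reported), without a figure. So compound 2 stands without a single number, and the one further value shown beside it is a limit (the limit of > 50000 nM in this assay, at which 1 of the 2 values shown sits), so no step between measured compounds can be sized.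

The step of interest leads from compound 2 to compound 3 `O=C(Nc1ncc(C(Oc2ccc3cc(Br)ccc3c2)c2ccc(Cl)cc2)s1)c1ccc(F)cc1`, which has not yet been tested in this assay. The change is (4-fluorophenyl)carbonyl in place of 2-ethylhexyl on a nitrogen on an aromatic ring.

Among the compounds with values here, both values so far point in one direction: compound 1 shows a limit in this assay and compound 2 is called not toxic. The account therefore expects no step beyond the scatter in this assay, with compound 3 most likely again at the limit, because compound 1 already sits there (the limit of > 50000 nM in this assay, at which 1 of the 2 values shown sits). For compound 3 the half-maximal cytotoxic concentration is estimated at 50000 nM, within 20000 nM to 120000 nM.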

Compound 3, half-maximal cytotoxic concentration: "not toxic" (no number reported)
Nothing numeric was reported for compound 3; no gap can be computed for the estimate.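

In this assay, within the data shown here, compound 2 gives "not toxic" (no number reported) and compound 3 gives "not toxic" (no number reported), so no step between them can be read. The compounds shown leave open whether (4-fluorophenyl)carbonyl in place of 2-ethylhexyl changes the half-maximal cytotoxic concentration at all. Compound 1 carries the only figure, and it is a limit: the limit of > 50000 nM in this assay, at which 1 of the 3 values shown sits.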